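A few compounds are considered here, and "the series" means these few. Any claim that something is new, unique, unknown or untested is made for them only; others in the source may bear on it.

Compound 2 `O=C(/C=C/c1cc2ccccc2[nH]c1=O)c1ccc(O)cc1` stands highest of the two numbers in an ADME assay on HCC 2998 cells (Homo sapiens) for cytotoxicity, read by sulforhodamine B assay, with a stated time of 24 h (a higher number here means that more compound is tolerated, a lower number that less compound is tolerated), where compound 2 gives 59600 nM; compound 1 `COc1ccc(C(=O)/C=C/c2cc3ccccc3[nH]c2=O)cc1` gives 29000 nM. Going by the values given here, the single step known, a 2.1-fold higher number from compound 1 to compound 2 (0.31 log units; beyond the scatter), is modest and concerns the oxygen substituent rather than the halogen. Compound 3 `O=C(/C=C/c1cc2ccccc2[nH]c1=O)c1ccc(Cl)cc1` differs from compound 2 by chloro in place of hydroxy on an aromatic carbon. Among the compounds with values here, with no chloro compound measured, that step bears only loosely, and a modest fall toward compound 1 is expected. Compound 3 is therefore estimated at 35000 nM, between 15000 nM and 80000 nM. The expected step is a 1.7-fold lower number from compound 2 to compound 3 (0.23 log units; within the scatter).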

Compound 3, concentration lethal to 50% of the cells: 59600 nM
The estimate for compound 3 lay 1.7-fold (0.23 log units) below the measured number; measured number inside the range.
By their numbers in this assay, from the lowest: compound 1; then compounds 2 and 3 (each within the scatter of the next).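

With chloro in place of hydroxy para to a large group, the result is no change at the digits printed from compound 2 to compound 3 (within the scatter), so at this position the higher number does not depend on a hydroxy group. Chloro in place of methoxy gives a 2.1-fold higher number from compound 1 to compound 3 (0.31 log units; beyond the scatter), which leaves compound 1, with its methoxy, as the only one of the three set apart from the others. Nothing available explains why these groups behave this way. Still open, from the compounds shown here alone, is whether an amine, a carboxylic acid or fluoro at this position would match compound 2 and compound 3, and whether a longer alkoxy chain would lower the number further than methoxy does.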